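Bromine in Place of a Larger Arm on the Ring

The source may hold more compounds than are shown below. What is called first, only, known or untested is meant among the compounds shown, and "the series" means these compounds.

Going by the values given here, compound 2 `CC(C)(C)Cc1c(/C=C/c2ccc(Cl)cc2)sc(N)c1C(=O)c1ccc(Cl)cc1` is one of two compounds measured so far: in an assay on CHO cells for displacement of a labelled ligand from adenosine receptor A3 (Homo sapiens), read by scintillation counting, tested at 10 uM (a lower number here means less inhibition, a higher number more inhibition at the concentration tested (going by the name of the read-out)), compound 2 gives 11%. The other, compound 1 `CC(C)(C)Cc1c(-c2ccc(F)cc2)sc(N)c1C(=O)c1ccc(Cl)cc1`, gives 9% in this assay, a number within the usual scatter of that of compound 2. Compound 3 `CC(C)(C)Cc1c(Br)sc(N)c1C(=O)c1ccc(Cl)cc1` is not yet measured; it differs from compound 2 by bromo in place of 2-(4-chlorophenyl)ethenyl on an aromatic carbon. Among the compounds with values here, the only step at the same position is a number 2 percentage points higher from compound 1 to compound 2 (within the scatter), which stayed within the scatter. The step of a number 1 percentage points lower from compound 2 to compound 3 (within the scatter) is therefore expected to be small as well. Compound 3 is estimated at 10%, between 0% and 25%.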

Compound 3, a percentage reported as inhibition, at one concentration (the size of the read-out at that concentration, not a potency): 1%
Estimate against measurement, compound 3: 9 percentage points above; the measured number falls inside the stated range.
By their numbers in this assay, from the lowest: compounds 3, 1 and 2 (each within the scatter of the next).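

Bromo removes the whole outer aromatic ring of either larger arm, and in the case of 2-(4-chlorophenyl)ethenyl nine heavy atoms give way to one, yet this assay gives a number 10 percentage points lower from compound 2 to compound 3 (within the scatter) and a number 8 percentage points lower from compound 1 to compound 3 (within the scatter). On this carbon, then, a single bromine atom and an arm carrying a further aromatic ring cannot be told apart by this read-out. Nothing available explains why the numbers stay so close. From the compounds shown here alone, whether an amine or a carboxylic acid on this carbon would move the number beyond the scatter remains open.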